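The source may hold more compounds than are shown below. What is called first, only, known or untested is meant among the compounds shown, and "the series" means these compounds.

Measured so far, in an ADME assay on MT4 cells (Homo sapiens) for cytotoxicity, read by MTT assay; on this read-out lower numbers stand for higher toxicity in this test and higher numbers for lower toxicity in this test:
- compound 1 `Cc1ccc(NC(=S)OCCc2ccccn2)cc1` gives 75000 nM
- compound 2 `CCc1ccc(NC(=S)OCCc2ccccn2)cc1` gives 44000 nM
- compound 3 `FC(F)(F)c1ccc(NC(=S)OCCc2ccccn2)cc1` gives 50000 nM

The three compounds share one core and differ only in the group on the aromatic ring. Compound 3 sits nearest to compound 2, a 1.1-fold higher number from compound 2 to compound 3 (0.06 log units; within the scatter), and furthest from compound 1, a 1.5-fold lower number from compound 1 to compound 3 (0.18 log units; within the scatter); all three numbers lie within the scatter of one another, so none of them can be called more or less toxic than the others.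

Going by the values given here, compound 4 `Fc1ccc(NC(=S)OCCc2ccccn2)cc1` has not yet been tested. fluoro in place of trifluoromethyl on an aromatic carbon The steps that bear on this change are those that swap the group at the same place on the ring: a 1.5-fold lower number from compound 1 to compound 3 (0.18 log units; within the scatter) and a 1.1-fold higher number from compound 2 to compound 3 (0.06 log units; within the scatter), together with a 1.7-fold lower number from compound 1 to compound 2 (0.23 log units; within the scatter). Every one of these stayed within the scatter, so swapping one small group for another at this place has so far left the numbers in this assay essentially unmoved. For compound 4 no step beyond the scatter in this assay is therefore expected. The expected step is a 1.1-fold higher number from compound 3 to compound 4 (0.04 log units; within the scatter). For compound 4 the estimate in this assay is 55000 nM, with a range from 25000 nM to 120000 nM.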

Compound 4, half-maximal cytotoxic concentration: > 100000 nM
Compound 4: a limit, no number (the forecaster's own chance of this, stated with the estimate: 15%); at least 1.8-fold (0.25 log units) between middle value and limit.
By their numbers in this assay, from the lowest: compounds 2, 3 and 1 (each within the scatter of the next). At a limit, above all of these: compound 4.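

Compound 4 reaches the top of the range read in this assay, and its reading is a limit of the test, not a number: the limit of > 100000 nM in this assay, at which 1 of the 4 values shown sits. Fluoro in place of ethyl gives an at least 2.2-fold higher number from compound 2 to compound 4 (0.35 log units; beyond the scatter), the first step at this place on the ring to pass the scatter, so the group here can move this number towards lower toxicity in this test. The other two steps, an at least 2.0-fold higher number from compound 3 to compound 4 (0.30 log units; that floor lies within the scatter) and an at least 1.3-fold higher number from compound 1 to compound 4 (0.12 log units; that floor lies within the scatter), have floors within the scatter, so they show no firm separation of compound 4 from compound 3 or compound 1, and only their floors are known.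

From the compounds shown here alone, how much toxicity compound 4 shows at higher concentrations remains unknown. The compounds shown also leave open what chloro, methoxy or an amine at this place would give.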